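The source may hold more compounds than are shown below. What is called first, only, known or untested is meant among the compounds shown, and "the series" means these compounds.

Measured in an ADME assay on Vero 76 cells (Chlorocebus sabaeus) for cytotoxicity, read by MTT assay, with a stated time of 96 h; on this read-out lower numbers stand for higher toxicity in this test and higher numbers for lower toxicity in this test:
- compound 1 `Brc1ccc(NCc2cn(-c3ccccc3)nc2-c2ccccc2)cc1`: 52000 nM
- compound 2 `Clc1ccc(NCc2cn(-c3ccccc3)nc2-c2ccc(Cl)cc2)cc1`: 90000 nM
- compound 3 `Cc1ccc(-c2nn(-c3ccccc3)cc2CNc2ccc(Cl)cc2)cc1`: > 100000 nM (a limit)

Compound 3 is known only as a limit, > 100000 nM, and not as a number.

Compound 4 `Clc1ccc(NCc2cn(-c3ccccc3)nc2-c2ccccc2)cc1` is reached by hydrogen in place of methyl on an aromatic carbon. The nearest measured step is an at least 1.1-fold higher number from compound 2 to compound 3 (0.04 log units; that floor lies within the scatter), methyl in place of chloro on an aromatic carbon. Among the compounds with values here, no measured step has hydrogen entering at this place.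

The estimate therefore leans on compound 1 at 52000 nM and compound 2 at 90000 nM, two values within the scatter of each other. The expected move in this assay is small and toward a lower number, an at least 1.4-fold lower number from compound 3 to compound 4 (0.15 log units; that floor lies within the scatter). Compound 4 is expected at 70000 nM, with an estimated range of 35000 nM to 100000 nM.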

Compound 4, half-maximal cytotoxic concentration: 65000 nM
Estimate against measurement, compound 4: 1.1-fold (0.03 log units) above, and the stated range covers the measured number.
By their numbers in this assay, from the lowest: compounds 1, 4 and 2 (each within the scatter of the next). At a limit, above all of these: compound 3.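

In this assay, the change from 4-methylphenyl to phenyl gives an at least 1.5-fold lower number from compound 3 to compound 4 (0.18 log units; that floor lies within the scatter). That step rests on a limit rather than a number for compound 3: the limit of > 100000 nM in this assay, at which 1 of the 4 values shown sits. Hydrogen in place of chloro at this position gives a 1.4-fold lower number from compound 2 to compound 4 (0.14 log units; within the scatter), and chloro in place of bromo gives a 1.3-fold higher number from compound 1 to compound 4 (0.10 log units; within the scatter), so neither change moves the number beyond the scatter.

Going by these compounds, how far the true value of compound 3 lies past its limit remains open. So does whether an amine or a carboxylic acid at this position would shift the number beyond the scatter.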